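The source may hold more compounds than are shown below. What is called first, only, known or untested is meant among the compounds shown, and "the series" means these compounds.

Measured so far:
- Compound 1, `CC(C)(C)c1ccc(CN2C(=O)S/C(=C\c3ccc(N)cc3)C2=O)cc1`: 94000 nM
- Compound 2, `C=C(Br)C(=O)Nc1ccc(/C=C2\SC(=O)N(Cc3ccc(C)cc3)C2=O)cc1`: 3400 nM
- Compound 3, `Nc1ccc(/C=C2\SC(=O)N(Cc3cccc(Cl)c3)C2=O)cc1`: 4700 nM

All three were tested in a functional assay on L1210 cells (Mus musculus) for cytotoxicity, read by cell counting, with a stated time of 2 days; a lower number here means a stronger inhibitor, a higher number a weaker inhibitor. Among the three numbers, compound 3 stands second highest. Its nearest neighbour is compound 2, whose value lies within the scatter of compound 3, so the two cannot be told apart. Its furthest neighbour is compound 1, whose value lies well beyond the scatter, so compound 1 is clearly the weaker of that pair.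

The next compound, compound 4, `Cc1ccc(CN2C(=O)S/C(=C\c3ccc(N)cc3)C2=O)cc1`, has not yet been measured in this assay. Compared with compound 3, the change is 4-methylphenyl in place of 3-chlorophenyl on a saturated chain carbon bound to an amide-type nitrogen in a ring.

Within the data shown here, no direct step between measured compounds exists for this exchange, so only an expectation can be given. Compound 1, which also carries an aminophenyl group but a larger substituted benzyl group, gives 94000 nM, far weaker than compound 3. Compound 4 is expected to land between those, with an estimated step of a 2.1-fold higher number from compound 3 to compound 4 (0.33 log units; beyond the scatter) toward a weaker value, possibly within the scatter. The estimate for compound 4 is 10000 nM, in the range 3000 nM to 35000 nM.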

Compound 4, half-maximal inhibitory concentration: 94000 nM
Estimate against measurement, compound 4: 9.4-fold (0.97 log units) below; measured number outside the range, above it.
By their numbers in this assay, from the lowest: compounds 2 and 3 (each within the scatter of the next); then compounds 1 and 4 (each within the scatter of the next).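

In this assay, 4-methylphenyl in place of 3-chlorophenyl on a saturated chain carbon bound to an amide-type nitrogen in a ring proves to be a large change, with a 20-fold higher number from compound 3 to compound 4 (1.30 log units; beyond the scatter). Hydrogen in place of (1-bromoethenyl)carbonyl on a nitrogen on an aromatic ring also matters, with a 28-fold higher number from compound 2 to compound 4 (1.44 log units; beyond the scatter), whereas methyl in place of tert-butyl on an aromatic carbon gives no change at the digits printed from compound 1 to compound 4 (within the scatter). Nothing available explains why these exchanges differ so much.

Compound 3 and compound 4 differ in both the group on the ring and its place, so a 3-methylphenyl or 4-chlorophenyl group would be needed to separate those two changes. An acetyl group on the aromatic nitrogen would test whether the bromine-bearing group is needed or whether a simpler amide gives a similar number.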